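A few compounds are considered here, and "the series" means these few. Any claim that something is new, unique, unknown or untested is made for them only; others in the source may bear on it.

Measured compounds in an ADME assay on HEK-293T cells (Homo sapiens) for cytotoxicity, read by MTT assay, tested at 100 uM; on this read-out lower numbers stand for a stronger effect and higher numbers for a weaker effect at the one concentration tested:
compound 1 `CC(C)c1cc(C(=O)Nc2ncc([N+](=O)[O-])s2)c(O)c(C(C)C)c1`, 7.1%;
compound 2 `CC(=O)Oc1c(C(=O)Nc2ncc([N+](=O)[O-])s2)cc(C(C)C)cc1C(C)C`, 20.6%;
compound 3 `O=C(Nc1ncc([N+](=O)[O-])s1)c1ccc([N+](=O)[O-])o1`, 67.3%.

Compound 3 gives the highest of the three numbers, that is the weakest effect at the single concentration. Compound 2 stands nearest to it and compound 1 furthest, both gaps beyond the scatter. Among the compounds with values here, the one measured step, a number 13.5 percentage points higher from compound 1 to compound 2 (beyond the scatter), is a modest rise and concerns acetyl in place of hydrogen on an oxygen on an aromatic ring; it belongs to the acylated part of the shared core and not to the five-membered aromatic ring with one oxygen.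

Compound 4 `O=C(Nc1ncc([N+](=O)[O-])s1)c1ccc(-c2ccc(Br)cc2)o1` differs from compound 3 as follows:
4-bromophenyl in place of nitro on an aromatic carbon

Within the data shown here, no measured step follows a nitro leaving or a 4-bromophenyl entering, so the step from compound 1 to compound 2 gives no direct guide here. What the values show is that compound 1 and compound 2, whose acyl part is a carbon-only aromatic ring, give the two lower numbers, while compound 3 with the nitro gives the highest. On that basis a lower number is expected for compound 4, with a step estimated at a number 27.3 percentage points lower from compound 3 to compound 4 (beyond the scatter), although the range is wide. For compound 4 in this assay the estimate is 40%, between 12% and 70%.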

Compound 4, a percentage reported as activity, at one concentration (the size of the read-out at that concentration, not a potency): 70.3%
Compound 4: middle estimate off by 30.3 percentage points, on the low side, outside the stated range (above it).
By their numbers in this assay, from the lowest: compound 1; then compound 2; then compounds 3 and 4 (each within the scatter of the next).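

In this assay, the exchange of nitro for 4-bromophenyl on an aromatic carbon of the five-membered aromatic ring with 1 oxygen gives a number 3 percentage points higher from compound 3 to compound 4 (within the scatter) and so stays within the scatter, although a group of 3 heavy atoms with no ring gives way to one of 7 heavy atoms with a six-membered aromatic ring of carbon only. The read-out at this position therefore does not depend on the nitro: with the 4-bromophenyl in its place, compound 4 gives 70.3% and stands level with compound 3. Nothing available accounts for this lack of change at the position.

Still open, from the compounds shown here alone, is whether this level holds for other groups at the same carbon, such as an amine, a carboxylic acid, a longer chain or a phenyl without the bromine. Within the data shown here, also open is how the read-out responds to a change of the nitro that compound 3 and compound 4 share on the other ring of the shared core, since every step so far leaves that group in place.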